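The source may report more compounds than this note shows. Statements on the series, on what has been measured and on what is new or still open speak of the compounds shown alone.

Compound 1 `O=C(Nc1ccc([N+](=O)[O-])cc1)Nc1nc(-c2cc3ccccc3o2)cs1`: 19300 nM
Compound 2 `O=C(Nc1nc(-c2cc3ccccc3o2)cs1)Nc1ccccc1[N+](=O)[O-]`: 20300 nM

In a physicochemical assay, with a stated time of 6 min (a lower number here means a stronger inhibitor, a higher number a weaker inhibitor), compound 2 gives 20300 nM, within the scatter of compound 1 at 19300 nM. Compound 3 `Cc1ccc(NC(=O)Nc2nc(-c3cc4ccccc4o3)cs2)cc1` differs from compound 2 by 4-methylphenyl in place of 2-nitrophenyl on an amide-type nitrogen, with 4-methylphenyl in place of 2-nitrophenyl on an amide-type nitrogen. Among the compounds with values here, the only measured step, a 1.1-fold higher number from compound 1 to compound 2 (0.02 log units; within the scatter), swaps 4-nitrophenyl for 2-nitrophenyl, so it bears only indirectly on this change. Within the data shown here, no measured compound lacks a nitrophenyl group, so the expectation is loose, and no change beyond the scatter is expected. The expected size is a 1.1-fold lower number from compound 2 to compound 3 (0.05 log units; within the scatter). Compound 3 is estimated at 18000 nM, with an expected range from 6000 nM to 50000 nM.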

Compound 3, half-maximal inhibitory concentration: 500 nM
Estimate against measurement, compound 3: 36-fold (1.56 log units) above, outside the stated range (below it).
By their numbers in this assay, from the lowest: compound 3; then compounds 1 and 2 (each within the scatter of the next).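

Within this assay the group on the amide-type nitrogen clearly matters: 4-methylphenyl in place of 2-nitrophenyl gives a 41-fold lower number from compound 2 to compound 3 (1.61 log units; beyond the scatter) and so a much stronger inhibitor, although moving the nitro group had changed nothing beyond the scatter. Methyl in place of nitro on an aromatic carbon gives a 39-fold lower number from compound 1 to compound 3 (1.59 log units; beyond the scatter) in the same direction. Nothing measured here explains this change.

Still open, from the compounds shown here alone, is whether an unsubstituted phenyl or a 4-aminophenyl group would stay close to compound 3 or to compound 1. Also open, going by these compounds, is whether 2-methylphenyl would match 4-methylphenyl.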